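Sulfonamide series: aryl variation on the sulfonamide nitrogen

This account rests on a few compounds, and the source may have more. Where it says the series, first, only, none or still open, it means among the compounds named here.

Compound 1 `O=C1NCCN1c1ccc(S(=O)(=O)Nc2ccc(C3CCCCC3)cc2)cc1` gives in a functional assay on M21 cells (Homo sapiens) for antiproliferative activity, read by sulforhodamine B assay, with a stated time of 48 h; a higher number here means a weaker inhibitor, a lower number a stronger inhibitor > 1000 nM, which is a limit of the assay.
Compound 2 `CCc1ccc(NS(=O)(=O)c2ccc(N3CCNC3=O)cc2)cc1` gives in this assay 480 nM.
Compound 3 `O=C1NCCN1c1ccc(S(=O)(=O)Nc2ccc(OC(F)F)cc2)cc1` gives in this assay 410 nM.

Compound 2 holds the higher of the two numbers, with compound 3 at a 1.2-fold lower number from compound 2 to compound 3 (0.07 log units; within the scatter), within the scatter. Compound 1 sits at the limit of > 1000 nM in this assay, at which 1 of the 3 values shown sits.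

Compound 4 `Cc1ccc(NS(=O)(=O)c2ccc(N3CCNC3=O)cc2)c(C)c1` differs from compound 2 by 2,4-dimethylphenyl in place of 4-ethylphenyl on a sulfonamide nitrogen. The steps bearing on this position are an at least 2.0-fold lower number from compound 1 to compound 2 (0.31 log units; beyond the scatter) and an at least 2.4-fold lower number from compound 1 to compound 3 (0.38 log units; beyond the scatter), both bounded by the limit of compound 1, and a 1.2-fold lower number from compound 2 to compound 3 (0.07 log units; within the scatter). The closest analogy, one small carbon group replaced by another, lies within the scatter. No step beyond the scatter is expected here: a 1.1-fold lower number from compound 2 to compound 4 (0.03 log units; within the scatter). Compound 4 is estimated at 450 nM, within 200 nM to 1100 nM.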

Compound 4, half-maximal inhibitory concentration: 150 nM
For compound 4 the middle estimate is 3.0-fold (0.48 log units) above the measured one, and the stated range ends above it.
By their numbers in this assay, from the lowest: compound 4; then compounds 3 and 2 (each within the scatter of the next). At a limit, above all of these: compound 1.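

In this assay, 2,4-dimethylphenyl in place of 4-ethylphenyl on the sulfonamide nitrogen gives a 3.2-fold lower number from compound 2 to compound 4 (0.51 log units; beyond the scatter). Going by these compounds alone, the two groups have the same heavy-atom count, so this position responds to how the carbons are arranged on the ring, which the earlier compounds, each differing in the group itself, did not show. Nothing measured here gives a reason for this step.

On these data alone, whether one methyl alone would carry the step remains open. So does the effect of a methoxy group, an amine or a carboxylic acid on this aryl ring.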